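The source may report more compounds than this note shows. Statements on the series, on what has been measured and on what is new or still open speak of the compounds shown alone.

In a functional assay on MCF7 cells (Homo sapiens) for cytotoxicity (a lower number here means a stronger inhibitor of growth, a higher number a weaker inhibitor of growth), compound 1 (`COc1ccc(NS(=O)(=O)c2c(F)c(F)c(F)c(Br)c2F)cc1`) gives 270 nM, while compound 2 (`COc1ccc(NS(=O)(=O)c2c(F)cc(F)c(F)c2F)cc1`) gives 4500 nM, the higher of the two numbers. Compound 3 (`COc1ccc(NS(=O)(=O)c2c(F)cc(F)cc2F)cc1`) differs from compound 2 by hydrogen in place of fluoro on an aromatic carbon. Among the measured compounds shown here, the one measured step that bears on this is the large 17-fold higher number from compound 1 to compound 2 (1.22 log units; beyond the scatter), with hydrogen in place of bromo on an aromatic carbon. Since fluoro rather than bromo leaves here, a smaller rise is expected in this assay, an estimated 2.2-fold higher number from compound 2 to compound 3 (0.35 log units; beyond the scatter). The expected value for compound 3 is 10000 nM, within 4000 nM to 30000 nM.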

Compound 3, concentration for 50% growth inhibition: > 50000 nM
Compound 3: no number, only a limit (the forecaster's own chance of this, stated with the estimate: 15%); at least 5.0-fold (0.69 log units) between middle value and limit.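

In this assay hydrogen in place of fluoro gives an at least 11-fold higher number from compound 2 to compound 3 (1.04 log units; beyond the scatter) at this position, meta to a large group, so a large step is not confined to bromo leaving: a single fluoro, one heavy atom, is enough. Going by these compounds, compound 3 gives > 50000 nM as a limit and not a number, so the full size of this step stays unknown. The reading stops at the edge of the assay: the limit of > 50000 nM in this assay, at which 1 of the 3 values shown sits. On these data alone, whether chloro, a methyl or an amine at this position would keep growth inhibition near that of compound 2 remains open.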